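Amine substituent variation on compound 1, toward compound 4

A few compounds are considered here, and "the series" means these few. Any claim that something is new, unique, unknown or untested is made for them only; others in the source may bear on it.

Compound 1 `COc1cc(/C=C/c2nc(NC3CC3)c3sccc3n2)cc(OC)c1OC` carries a cyclopropylamino group on the shared core and gives 6030 nM in a functional assay on RAW264.7 cells (Mus musculus) for inhibition, read by Griess assay, with stated times of 1 h and 24 h; a lower number here means a stronger inhibitor, a higher number a weaker inhibitor. This is the lowest number of the three, though the numbers of compound 2 and compound 3 both lie within the scatter of it. Compound 2 `COc1cc(/C=C/c2nc(NCc3ccccc3)c3sccc3n2)cc(OC)c1OC` gives 8260 nM in this assay, and compound 3 `COc1cc(/C=C/c2nc(NCc3ccc(Cl)cc3)c3sccc3n2)cc(OC)c1OC` gives 9050 nM. The step of a 1.4-fold higher number from compound 1 to compound 2 (0.14 log units; within the scatter) and the step of a 1.5-fold higher number from compound 1 to compound 3 (0.18 log units; within the scatter) both stay within the scatter, as does the step of a 1.1-fold higher number from compound 2 to compound 3 (0.04 log units; within the scatter).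

Compound 4 `COc1cc(/C=C/c2nc(NCc3ccncc3)c3sccc3n2)cc(OC)c1OC` has not been measured in this assay. It differs from compound 1 by (pyridin-4-yl)methyl in place of cyclopropyl on a nitrogen on an aromatic ring, so cyclopropylamino becomes ((pyridin-4-yl)methyl)amino, the entering group bringing one six-membered aromatic ring with one hetero atom and one hydrogen-bond acceptor. The closest comparisons are the benzyl and 4-chlorobenzyl replacements on the same nitrogen, each a small shift, so the step of a 1.3-fold higher number from compound 1 to compound 4 (0.12 log units; within the scatter) is expected to be of comparable size and not beyond the scatter. Compound 4 is therefore estimated at 8000 nM, with a range of 4000 nM to 16000 nM.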

Compound 4, half-maximal inhibitory concentration: 6350 nM
Estimate against measurement, compound 4: 1.3-fold (0.10 log units) above; low and high end bracket the measured number.
By their numbers in this assay, from the lowest: compounds 1, 4, 2 and 3 (each within the scatter of the next).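

In this assay a ring carrying a hetero atom and a hydrogen-bond acceptor enters on the nitrogen on the aromatic ring, and a 1.1-fold higher number from compound 1 to compound 4 (0.02 log units; within the scatter) shows that this change does not separate the new group from cyclopropyl. With the saturated chain carbon kept, pyridin-4-yl in place of phenyl gives a 1.3-fold lower number from compound 2 to compound 4 (0.11 log units; within the scatter) and pyridin-4-yl in place of 4-chlorophenyl gives a 1.4-fold lower number from compound 3 to compound 4 (0.15 log units; within the scatter) so neither exchange of the ring resolves a difference, and all four amine substituents shown remain within the scatter of each other. No measurement at hand accounts for this flat result.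

Still open, going by these compounds, is whether any group on this nitrogen moves the number beyond the scatter. A carboxylic acid or a longer chain ending in an amine would test that, as would pyridin-2-yl in place of pyridin-4-yl.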